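The source may report more compounds than this note shows. Statements on the series, on what has been measured and on what is new or still open speak of the compounds shown alone.

Two sulfonamide diamides have been tested in a functional assay on IMR-32 cells (Homo sapiens) for cytotoxicity, read by MTT assay, tested at 60 ug/mL; on this read-out lower numbers stand for less inhibition and higher numbers for more inhibition at the one concentration tested (going by the name of the read-out). Compound 1 `O=C(CCC(NS(=O)(=O)c1cc(Cl)ccc1Cl)C(=O)NCc1ccccc1)NCc1ccccc1` gives 13.4%. Compound 2 `O=C(CCC(NS(=O)(=O)c1ccc(Br)cc1)C(=O)NC1CCCCC1)NC1CCCCC1` gives 18.4% in this assay. The gap between compound 2 and compound 1 is within the usual scatter of repeated measurements, so the two numbers cannot be told apart, and both stand for weak inhibition at the single concentration used. Within the data shown here, no pair of measured compounds differs in one place only, so no single structural step has yet been measured.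

Compound 3 `O=C(CCC(NS(=O)(=O)c1ccc(Cl)c(Cl)c1)C(=O)NC1CCCCC1)NC1CCCCC1` is the next compound to be measured in this assay. It differs from compound 2 in one place (3,4-dichlorophenyl in place of 4-bromophenyl on a sulfonyl sulfur). The two measured compounds carry different halogenated phenyl groups on the sulfonyl sulfur and different amide substituents, yet sit within the scatter of one another, which gives no basis for expecting a change beyond the scatter here. The step from compound 2 to compound 3 is therefore expected to be small, a number 1.4 percentage points lower from compound 2 to compound 3 (within the scatter), in no particular direction. Compound 3 is estimated to give 17% in this assay, with a range from 5% to 30%.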

Compound 3, a percentage reported as inhibition, at one concentration (the size of the read-out at that concentration, not a potency): 24%
Compound 3: the middle estimate sits 7 percentage points below what was measured, and the stated range covers the measured number.
By their numbers in this assay, from the lowest: compounds 1, 2 and 3 (each within the scatter of the next, the first and the last beyond it).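

Among these compounds, this is the first single change that can be read in this assay: with the rest of the molecule the same, 3,4-dichlorophenyl in place of 4-bromophenyl on a sulfonyl sulfur gives a number 5.6 percentage points higher from compound 2 to compound 3 (within the scatter). At this position, then, a phenyl group bearing one bromine can be exchanged for one bearing two chlorines, with the heavy-atom count going from 7 to 8, and the read-out stays within the scatter, so this change has no effect that can be distinguished here. Nothing available explains the result or links it to any property of either group.

Going by these compounds, all three compounds carry a halogenated phenyl group on the sulfonyl sulfur, so it remains open how this assay would respond to a different group there, such as an unsubstituted phenyl, a methoxyphenyl or a phenyl bearing a carboxylic acid. Among the compounds shown here, the contribution of the amide substituents also remains open, as compound 1 differs from each of the other two in more than one place and no single step to it can be read.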